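The source may report more compounds than this note shows. Statements on the series, on what has been measured and on what is new or still open speak of the compounds shown alone.

Working notes on the series in an ADME assay on J774 cells (Mus musculus) for cytotoxicity (a lower number here means that less compound is needed, a higher number that more compound is needed for the effect), starting from compound 3 `COC(=O)c1c[nH]c2ccccc2c1=O`. On these numbers compound 3 gives > 20000 nM, which is a limit of the assay and not a number. Compound 1 `COC(=O)c1c[nH]c2cc(OCCOc3ccccc3)ccc2c1=O` gives > 20000 nM, which is also a limit. Compound 2 `CCCCc1ccc2[nH]cc(C(=O)OC)c(=O)c2c1` gives > 20000 nM, again a limit. The whole set therefore comes down to the limit of > 20000 nM in this assay, at which 3 of the 3 values shown sit, and no value in this assay can be placed in order against another.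

Compound 4 `COC(=O)c1c[nH]c2cc(-c3ccccc3)ccc2c1=O` is reached from compound 3 by one change: phenyl in place of hydrogen on an aromatic carbon. In words, this is phenyl in place of hydrogen on an aromatic carbon.

Going by the values given here, the only measured step that bears on this change is the loss of butyl on an aromatic carbon, a step that the two limits leave unreadable from compound 2 to compound 3. It gives neither a size nor a direction to carry over. The side chain of compound 1 likewise yields no number. With nothing readable, no step beyond the usual scatter is expected in this assay, and no direction can be argued. The estimated step is a number no higher from compound 3 to compound 4 (the limit leaves the size open). For compound 4 the expected value is 20000 nM, with an estimated range from 9000 nM to 40000 nM.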

Compound 4, half-maximal effective concentration: > 20000 nM
Compound 4 gave a limit, no number; the forecaster's own chance of this, stated with the estimate: 75%; the middle value lies on the limit itself.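

No new step can be read between compound 3 and compound 4 in this assay: the limit of > 20000 nM in this assay, at which 4 of the 4 values shown sit.

The compounds shown leave open where compound 1, compound 2, compound 3 and compound 4 would stand as numbers in this assay, and whether any change on the shared core shifts the read-out at all.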